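A few compounds are considered here, and "the series" means these few. Any claim that something is new, unique, unknown or untested is made for them only; others in the source may bear on it.

Measured so far in a functional assay for agonist activity at G protein-coupled receptor 88 (Homo sapiens), read by HTRF and cAMP accumulation; on this read-out higher numbers stand for an effect only at larger amounts of compound and lower numbers for an effect already at smaller amounts:
compound 1 `CC(C)C[C@H](N)CN(C(=O)[C@@H]1C[C@H]1c1ccccc1)c1ccc(C2=CCCCC2)cc1` gives 1200 nM
compound 2 `COc1ccc(-c2ccc(N(C[C@@H](N)CC(C)C)C(=O)[C@@H]3C[C@H]3c3ccccc3)cc2)cc1` gives 330 nM
compound 3 `CC(C)C[C@H](N)CN(C(=O)[C@@H]1C[C@H]1c1ccccc1)c1ccc(-c2ccc(F)cc2)cc1` gives 900 nM

Among these three numbers compound 3 stands second highest; its nearest neighbour is compound 1, a 1.3-fold lower number from compound 1 to compound 3 (0.12 log units; within the scatter), and its furthest is compound 2, a 2.7-fold higher number from compound 2 to compound 3 (0.44 log units; beyond the scatter). The change to compound 4 `CC(C)C[C@H](N)CN(C(=O)[C@@H]1C[C@H]1c1ccccc1)c1ccc(-c2cccc(F)c2)cc1` is 3-fluorophenyl in place of 4-fluorophenyl on an aromatic carbon. Within the data shown here, no measured step relocates a fluorine within one ring: the two recorded steps, a 3.6-fold lower number from compound 1 to compound 2 (0.56 log units; beyond the scatter) and a 2.7-fold higher number from compound 2 to compound 3 (0.44 log units; beyond the scatter), each exchange one whole group for another, so they bear on this step only loosely, by showing that changes at this part of the molecule so far shift the number by modest amounts at most. A shift of a single fluorine within an otherwise unchanged ring is expected to move the number less than those exchanges did, and no step beyond the scatter is expected in this assay. Compound 4 is therefore estimated at 900 nM, with a range from 350 nM to 2500 nM. The step this estimate implies, no change at the digits printed from compound 3 to compound 4 (within the scatter), is expected to lie within the scatter.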

Compound 4, half-maximal effective concentration: 2100 nM
Estimate against measurement, compound 4: 2.3-fold (0.37 log units) below; the measured number falls inside the stated range.
By their numbers in this assay, from the lowest: compound 2; then compounds 3, 1 and 4 (each within the scatter of the next, the first and the last beyond it).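

In this assay the place of a single fluorine matters: 3-fluorophenyl in place of 4-fluorophenyl, with the same atoms and counts in the group, gives a 2.3-fold higher number from compound 3 to compound 4 (0.37 log units; beyond the scatter) within this series. The 3-fluorophenyl group also yields the largest step shown, a 6.4-fold higher number from compound 2 to compound 4 (0.80 log units; beyond the scatter) against 4-methoxyphenyl, while against cyclohex-1-en-1-yl the step is a 1.8-fold higher number from compound 1 to compound 4 (0.24 log units; within the scatter) and does not separate the two compounds. No measurement available here accounts for the difference between the two fluorine places.

As far as these compounds go, it remains open whether 3-methoxyphenyl would depart from 4-methoxyphenyl in the same direction as the fluorine pair, so the effect of place is so far seen for fluorine alone. From the compounds shown here alone, how a 2-fluorophenyl, 3,4-difluorophenyl or 4-carboxyphenyl group would stand also remains open.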